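Compound 2 to compound 3: a longer chain

The source may report more compounds than this note shows. Statements on the series, on what has been measured and on what is new or still open speak of the compounds shown alone.

Compound 1 `CCCCCC(=O)Nc1nc(N)nc2c1ncn2[C@H]1CO[C@@H](CO)O1`: > 100000 nM (a limit)
Compound 2 `CCCCCCCCCCCCCC(=O)Nc1nc(N)nc2c1ncn2[C@H]1CO[C@@H](CO)O1`: 4600 nM

Within the data shown here, in a functional assay on CCRF-CEM cells (Homo sapiens) for cytotoxicity (on this read-out higher numbers stand for lower toxicity in this test and lower numbers for higher toxicity in this test), compound 2 gives 4600 nM, the only value so far that is not a limit. Compound 3 `CCCCCCCC/C=C\CCCCCCCC(=O)Nc1nc(N)nc2c1ncn2[C@H]1CO[C@@H](CO)O1` differs from compound 2 by dec-1-en-1-yl in place of hexyl on a saturated chain carbon, seven bonds along the chain from a carbonyl carbon. Among the measured compounds shown here, one measured step bears on this, also a chain extension: an at least 21-fold lower number from compound 1 to compound 2 (1.33 log units; beyond the scatter), large and beyond the scatter. That single step does not show whether the trend continues, so no step beyond the scatter is expected in this assay, with a slight lean towards lower numbers. The expected step is a 1.2-fold lower number from compound 2 to compound 3 (0.06 log units; within the scatter). For compound 3 the estimate is 4000 nM, with an expected range of 1500 nM to 15000 nM.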

Compound 3, half-maximal cytotoxic concentration: 13000 nM
For compound 3 the middle estimate is 3.3-fold (0.51 log units) below the measured one, within the range that was stated.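

In this assay, lengthening the chain no longer goes with a lower number: dec-1-en-1-yl in place of hexyl, at this position seven bonds along the chain from a carbonyl carbon, gives a 2.8-fold higher number from compound 2 to compound 3 (0.45 log units; beyond the scatter). The chain of compound 3 still keeps a clear distance from the short chain, with an at least 7.6-fold lower number from compound 1 to compound 3 (0.88 log units; beyond the scatter). That second step is open-ended, since the value of compound 1 is a limit: the limit of > 100000 nM in this assay, at which 1 of the 3 values shown sits.

The compounds shown leave open whether the added length or the double bond goes with the higher number. A fully saturated chain of the same length as in compound 3 would separate the two.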